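This account rests on a few compounds, and the source may have more. Where it says the series, first, only, none or still open, it means among the compounds named here.

Within the data shown here, in an ADME assay on PC-12 cells (Rattus norvegicus) for cytotoxicity, read by MTT assay, with a stated time of 24 h (on this read-out lower numbers stand for higher toxicity in this test and higher numbers for lower toxicity in this test), three compounds built on a shared core have numbers so far. Compound 1 `COc1ccc(N2CCN(CC#CCOC(=O)c3sc4ncnc(N5CCCCC5)c4c3C)CC2)cc1` gives 140 ug/mL, compound 2 `Cc1c(C(=O)OCC#CCN2CCN(c3cc(C4CC4)ccc3C#N)CC2)sc2ncnc(N3CCCCC3)c12` gives 148 ug/mL, and compound 3 `Cc1c(-c2nnc(-c3ccccc3)o2)sc2ncnc(N3CCCCC3)c12` gives 146 ug/mL. All three values lie within the usual scatter of repeated measurements, so compound 3 stands level with the other two, and no ranking can be read from them.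

Compound 4 `COc1ccc(-c2nnc(-c3sc4ncnc(N5CCCCC5)c4c3C)o2)cc1` is compound 3 with a single change, methoxy in place of hydrogen on an aromatic carbon, which turns phenyl to 4-methoxyphenyl. Among the measured compounds shown here, no measured pair shows this exact change. The nearest evidence is a 1.1-fold higher number from compound 1 to compound 2 (0.02 log units; within the scatter), where 2-cyano-5-cyclopropylphenyl replaces 4-methoxyphenyl on an amine nitrogen in a ring, and that step stays within the scatter. It sits on a different part of the molecule, so it is only a loose guide. Compound 1 also carries a 4-methoxyphenyl group and gives 140 ug/mL, level with compound 3.

The expected result is therefore no shift beyond the scatter in either direction, with an estimated step of a 1.0-fold lower number from compound 3 to compound 4 (0.02 log units; within the scatter). For compound 4 the estimated value is 140 ug/mL, with an expected range from 80 ug/mL to 240 ug/mL.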

Compound 4, half-maximal cytotoxic concentration: 124 ug/mL
For compound 4 the middle estimate is 1.1-fold (0.05 log units) above the measured one, within the range that was stated.
By their numbers in this assay, from the lowest: compounds 4, 1, 3 and 2 (each within the scatter of the next).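

In this assay, methoxy in place of hydrogen on an aromatic carbon of the phenyl ring, para to a large group, gives a 1.2-fold lower number from compound 3 to compound 4 (0.07 log units; within the scatter), so this single change does not separate the two compounds. Among these compounds, this is the first direct reading of the change at this position: until now, 4-methoxyphenyl had been seen only on an amine nitrogen in a ring, in compound 1, while here it takes the place of phenyl and the result stays within the scatter of compound 3. Nothing measured here explains why the step is so small, and no separate measurement bears on this result.

What remains open is whether this position can shift the number at all, since hydrogen and methoxy are the only two groups shown there. A carboxylic acid, an amine or a longer chain such as butoxy on the same carbon could give a step beyond the scatter or could leave the number where it is, and the four compounds shown cannot tell which.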